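The source may hold more compounds than are shown below. What is called first, only, known or untested is meant among the compounds shown, and "the series" means these compounds.

Measured compounds:

Compound 1 `COc1cccc(Sc2c(NS(=O)(=O)c3ccc(C(C)(C)C)cc3)noc2CCCC#N)c1`: in an assay on A7R5 cells for displacement of a labelled ligand from Endothelin-1 receptor (Rattus norvegicus) (a higher number here means a weaker inhibitor, a lower number a stronger inhibitor), compound 1 gives 1300 nM.
Compound 2 `CSc1c(NS(=O)(=O)c2ccc(C(C)(C)C)cc2)noc1C`: in this assay compound 2 gives > 100000 nM, which is a limit of the assay rather than a number.

Among the compounds with values here, compound 1 is therefore the only compound here with an actual number in this assay; the other result is the limit of > 100000 nM in this assay, at which 1 of the 2 values shown sits, so no step between measured compounds can be stated, and nothing can be said of how the two values compare beyond that compound 1 has a measurable number and compound 2 does not.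

The unmeasured compound 3 `COc1cccc(Sc2c(NS(=O)(=O)c3ccc(C(C)(C)C)cc3)noc2CCC=O)c1` differs from compound 1 in a single place: formyl in place of cyanomethyl on a saturated chain carbon, two bonds along the chain from an aromatic carbon. The shared core, the sulfonamide and the aryl sulfide are unchanged; only the end of the saturated chain is altered, and the chain becomes shorter by the count given.

Within the data shown here, with no measured step to lean on, the expectation is a small shift in this assay, if any, since the change leaves most of compound 1 intact. Compound 3 is expected to give about 2000 nM, between 600 nM and 7000 nM, a step of a 1.5-fold higher number from compound 1 to compound 3 (0.19 log units; within the scatter) that is estimated to stay near the scatter.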

Compound 3, half-maximal inhibitory concentration: 380 nM
The estimate for compound 3 lay 5.3-fold (0.72 log units) above the measured number, outside the stated range (below it).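

In this assay, the end of the saturated chain proves to be a position that responds to change: formyl in place of cyanomethyl, on a saturated chain carbon two bonds along the chain from an aromatic carbon, gives a 3.4-fold lower number from compound 1 to compound 3 (0.53 log units; beyond the scatter). Within the data shown here, this is the first step between measured compounds that can be read, and although modest, it lies beyond the usual scatter, so the nitrile is not required for a measurable number here and a carbonyl at the end of a shorter chain gives a stronger inhibitor. Nothing shown here accounts for why the number moves in this direction.

The change replaces the end group and shortens the chain in a single step, and the compounds shown do not separate these two parts of it. From the compounds shown here alone, how a carboxylic acid, an amine or a longer chain ending in a nitrile would behave at this same place also remains open.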